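From methyl to phenylsulfonyl on the ring nitrogen

The compounds below may be only part of what the source reports. "The series", "measured", "known", "first", "only" and "open" are said of these compounds alone.

Compound 1 `CN1C/C(=C\c2cccnc2)C(=O)/C(=C/c2ccccc2C(F)(F)F)C1`: 3900 nM
Compound 2 `CN1C/C(=C\c2ccncc2)C(=O)/C(=C/c2ccccc2C(F)(F)F)C1`: 4100 nM
Compound 3 `Cc1ccc(S(=O)(=O)N2C/C(=C\c3cccnc3)C(=O)/C(=C/c3ccccc3F)C2)cc1`: 10300 nM

In a functional assay on SMMC-7721 cells (Homo sapiens) for cytotoxicity, read by MTT assay, with a stated time of 24 h (a higher number here means a weaker inhibitor, a lower number a stronger inhibitor), compound 1 gives 3900 nM, level with compound 2, and both numbers lie under that of compound 3. Compound 4 `O=C1/C(=C/c2cccnc2)CN(S(=O)(=O)c2ccccc2)C/C1=C\c1ccccc1C(F)(F)F` carries phenylsulfonyl in place of methyl on an amine nitrogen in a ring. Within the data shown here, the only measured step, a 1.1-fold higher number from compound 1 to compound 2 (0.02 log units; within the scatter), concerns the pyridinyl group and does not touch that nitrogen. The closest guide is compound 3, which also has a sulfonyl group there and gives 10300 nM, although it differs in other groups too. The expected change is a 1.9-fold higher number from compound 1 to compound 4 (0.28 log units; within the scatter), towards a higher number. For compound 4 the estimate is 7500 nM, with an expected range of 3000 nM to 16000 nM.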

Compound 4, half-maximal inhibitory concentration: 10900 nM
The estimate for compound 4 lay 1.5-fold (0.16 log units) below the measured number; the range from low to high includes it.
By their numbers in this assay, from the lowest: compounds 1 and 2 (each within the scatter of the next); then compounds 3 and 4 (each within the scatter of the next).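

The ring nitrogen now has a direct reading in this assay: with nothing else changed, phenylsulfonyl in place of methyl gives a 2.8-fold higher number from compound 1 to compound 4 (0.45 log units; beyond the scatter), so this change weakens inhibition. Compound 3 could not show this, since it differs from the methyl compounds in other groups too. No measurement at hand accounts for the step.

The compounds shown leave open how an acetyl or benzyl group on that nitrogen would read. They also leave open whether phenylsulfonyl has the same effect alongside pyridin-4-yl.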